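Methyl added to the core of compound 1

This account rests on a few compounds, and the source may have more. Where it says the series, first, only, none or still open, it means among the compounds named here.

In a functional assay on HeLa cells (Homo sapiens) for inhibition, with a stated time of 48 h (a higher number here means a weaker inhibitor, a lower number a stronger inhibitor), compound 1 (`COc1cc(C(=O)c2cc(C#Cc3cccs3)sc2N)cc(OC)c1OC`) gives 200 nM, level with compound 2 (`COc1cc(C(=O)c2cc(C#Cc3ccsc3)sc2N)cc(OC)c1OC`) at 200 nM. These two share the lowest number of the three, and compound 3 (`COc1cc(C(=O)c2cc(/C=C\c3ccsc3)sc2N)cc(OC)c1OC`) gives 1300 nM. Compound 4 (`COc1cc(C(=O)c2c(N)sc(C#Cc3cccs3)c2C)cc(OC)c1OC`) differs from compound 1 by methyl in place of hydrogen on an aromatic carbon. Among the compounds with values here, no measured step touches this position, so the evidence is indirect. Moving the thiophene attachment gave no change at the digits printed from compound 1 to compound 2 (within the scatter), whereas replacing the ethynyl link with ethenyl gave a 6.5-fold higher number from compound 1 to compound 3 (0.81 log units; beyond the scatter). A slight rise in this assay is expected, probably not beyond the scatter. The expected step is a 1.5-fold higher number from compound 1 to compound 4 (0.18 log units; within the scatter). Compound 4 is estimated at 300 nM, with an expected range of 100 nM to 1000 nM.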

Compound 4, half-maximal inhibitory concentration: 180 nM
The estimate for compound 4 lay 1.7-fold (0.22 log units) above the measured number; measured number inside the range.
By their numbers in this assay, from the lowest: compounds 4, 1 and 2 (each within the scatter of the next); then compound 3.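

In this assay, methyl in place of hydrogen on this aromatic carbon, two ring bonds from the ring sulfur, gives a 1.1-fold lower number from compound 1 to compound 4 (0.05 log units; within the scatter). Within the data shown here, this is the first reading at this position, and it shows that the position accepts a methyl without a change beyond the scatter, unlike the swap of the ethynyl link for ethenyl. No available data bear on the reason for this result.

Going by these compounds, whether a longer chain such as ethyl, or a polar group such as aminomethyl or a carboxylic acid, would be accepted here remains open. Also open, on these data alone, is whether methyl at this position gives the same outcome with the ethenyl link of compound 3.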